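The source may hold more compounds than are shown below. What is called first, only, known or untested is meant among the compounds shown, and "the series" means these compounds.

Compound 1, `CCCS(=O)(=O)Nc1ccc(F)c(C(=O)c2n[nH]c3ncc(-c4ccccc4)cc23)c1F`, gives 2.4% in an assay for binding affinity to dual specificity mitogen-activated protein kinase kinase 4 (Homo sapiens), read by KINOMEscan, tested at 100 nM; a higher number here means a weaker effect of the compound at the concentration tested, a lower number a stronger effect. Compound 2, `CCCS(=O)(=O)Nc1ccc(F)c(C(=O)c2n[nH]c3ncc(-c4ccc(C)c(C)c4)cc23)c1F`, gives 20%.

Of these two numbers, compound 2 stands highest, and its nearest neighbour is compound 1, whose number is lower by a number 17.6 percentage points higher from compound 1 to compound 2 (beyond the scatter). That single step, the exchange of phenyl for 3,4-dimethylphenyl on an aromatic carbon, is the only one measured, and it was modest in size.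

Compound 3 is `CCCS(=O)(=O)Nc1ccc(F)c(C(=O)c2n[nH]c3ncc(-c4cccc(C(F)(F)F)c4)cc23)c1F`. It differs from compound 2 by 3-(trifluoromethyl)phenyl in place of 3,4-dimethylphenyl on an aromatic carbon. Among the compounds with values here, no measured step swaps one substituted phenyl for another, so the step from compound 1 to compound 2 bears on it only loosely: it shows that a change on this ring can move the read-out by a modest amount in either direction. The expected step of a number 8 percentage points lower from compound 2 to compound 3 (within the scatter) is therefore small, with wide uncertainty. Compound 3 is estimated at 12%, within a range from 1% to 40%.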

Compound 3, a percentage reported as activity, at one concentration (the size of the read-out at that concentration, not a potency): 57%
For compound 3 the middle estimate is 45 percentage points below the measured one, and the stated range ends below it.
By their numbers in this assay, from the lowest: compound 1; then compound 2; then compound 3.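

In this assay, the phenyl ring on this aromatic carbon proves much less tolerant of substitution than the earlier step alone could show: placing trifluoromethyl where hydrogen stood gives a number 54.6 percentage points higher from compound 1 to compound 3 (beyond the scatter) and a large loss of effect. Exchanging 3,4-dimethylphenyl for 3-(trifluoromethyl)phenyl gives a number 37 percentage points higher from compound 2 to compound 3 (beyond the scatter) and is also a large step, so the read-out depends on which substituted ring is present and not only on the ring carrying substituents. Among these three compounds, both substituted rings weaken the effect relative to the plain phenyl of compound 1, and none goes against this.

On these data alone, it stays open how a phenyl ring carrying an amine, a methoxy group or a carboxylic acid would read out here. Nothing available explains why these groups differ so much.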